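This account rests on a few compounds, and the source may have more. Where it says the series, first, only, none or still open, it means among the compounds named here.

Compound 3, `C=C1CC[C@@H]2[C@](C)(CNCc3ccc(OC)cc3)[C@H](O)CC[C@@]2(C)[C@@H]1/C=C/C1=CCOC1=O`, is the better-placed of the two compounds that give a number in a functional assay on BMMC cells (Mus musculus, strain C57BL/6) for inhibition, with stated times of 5 days and 48 h; on this read-out lower numbers stand for stronger inhibition and higher numbers for weaker inhibition: compound 3 gives 750 nM, the lowest of the two values shown. Its nearest neighbour is compound 2, `C=C1CC[C@@H]2[C@](C)(CO)[C@H](O)CC[C@@]2(C)[C@@H]1C/C=C1\C=COC1=O`, which in this assay gives 2770 nM. Compound 1, `C=C1CC[C@@H]2[C@](C)(CO)[C@H](O)CC[C@@]2(C)[C@@H]1CCC1C(=O)OC[C@H]1O`, gives only a limit in this assay, > 30000 nM, as the evidence the limit of > 30000 nM in this assay, at which 1 of the 3 values shown sits, records.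

Within the data shown here, the one measured step, an at least 10-fold lower number from compound 1 to compound 2 (1.03 log units; beyond the scatter), concerns a replacement on a saturated chain carbon bound to a saturated ring carbon, far from the aromatic ring that changes here. Compound 4, `C=C1CC[C@@H]2[C@](C)(CNCc3ccc(Cl)cc3)[C@H](O)CC[C@@]2(C)[C@@H]1/C=C/C1=CCOC1=O`, differs from compound 3 by chloro in place of methoxy on an aromatic carbon. No measured step touches this aromatic ring, so nothing among the shown compounds points to a direction for the change, and the expected step is none beyond the scatter. The step from compound 3 to compound 4 in this assay is therefore estimated as no change at the digits printed from compound 3 to compound 4 (within the scatter). Compound 4 is accordingly expected to give about 750 nM, within a range from 300 nM to 2000 nM.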

Compound 4, half-maximal inhibitory concentration: 420 nM
Estimate against measurement, compound 4: 1.8-fold (0.25 log units) above; low and high end bracket the measured number.
By their numbers in this assay, from the lowest: compounds 4 and 3 (each within the scatter of the next); then compound 2. At a limit, above all of these: compound 1.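

Chloro in place of methoxy on this aromatic carbon, para to a large group, gives a 1.8-fold lower number from compound 3 to compound 4 (0.25 log units; within the scatter) in this assay. This is the first step shown at this aromatic ring, and it finds the 4-methoxybenzyl and 4-chlorobenzyl compounds indistinguishable on this read-out, even though the two groups differ in their atoms and the methoxy group brings a hydrogen-bond acceptor that chloro lacks. Nothing measured among the compounds shown bears on why the read-out holds across this change.

From the compounds shown here alone, whether a carboxylic acid or a dimethylamino group on this aromatic carbon would keep the number in the same range in this assay stays open. What the (4-chlorobenzyl)amino group itself contributes also stays open, as no step shown links compound 3 or compound 4 to a compound without such a group.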